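Replacing the 3-chlorophenyl group of compound 1

A few compounds are considered here, and "the series" means these few. Any claim that something is new, unique, unknown or untested is made for them only; others in the source may bear on it.

In a functional assay on MCF7 cells (Homo sapiens) for inhibition, read by sulforhodamine B assay (on this read-out higher numbers stand for weaker inhibition of growth and lower numbers for stronger inhibition of growth), compound 1 (`Cc1ccc2[nH]c(-c3ccc(-c4ccc(-c5cccc(Cl)c5)cc4)cc3)nc2c1`) gives 1210 nM and holds the lower of the two actual numbers available. Compound 2 (`Clc1cccc(-c2ccc(-c3ccc(-c4nc5ccccc5[nH]4)cc3)cc2)c1`) gives 36300 nM in this assay and supplies the other number. Compound 3 (`COc1cc(-c2ccc(-c3ccc(-c4nc5c(O)cccc5[nH]4)cc3)cc2)cc(OC)c1OC`) gives < 100 nM in this assay and that value is a limit of the assay, not a number.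

Compound 4 (`Cc1ccc2[nH]c(-c3ccc(-c4ccc(-c5ccc(C(F)(F)F)cc5)cc4)cc3)nc2c1`) has not yet been measured. In it, 4-(trifluoromethyl)phenyl stands in place of 3-chlorophenyl on an aromatic carbon (4-(trifluoromethyl)phenyl in place of 3-chlorophenyl on an aromatic carbon). For the measured compounds named here, the only measured step is hydrogen in place of methyl on an aromatic carbon, which gives a 30-fold higher number from compound 1 to compound 2 (1.48 log units; beyond the scatter) and is large. That step does not touch the group now being exchanged, as compound 1 and compound 2 both carry 3-chlorophenyl, and compound 4 keeps the methyl. Going by the values given here, no measured step therefore gives a direction or size for this exchange, so no change beyond the scatter is expected in this assay in either direction. The size of a 30-fold higher number from compound 1 to compound 2 (1.48 log units; beyond the scatter) still argues for a wide range. The expected step is a 1.2-fold higher number from compound 1 to compound 4 (0.09 log units; within the scatter) and it lies within the scatter. Compound 4 is estimated at 1500 nM with a range from 300 nM to 7500 nM in this assay once it is measured.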

Compound 4, concentration for 50% growth inhibition: 31000 nM
Estimate against measurement, compound 4: 21-fold (1.32 log units) below, outside the stated range (above it).
By their numbers in this assay, from the lowest: compound 1; then compounds 4 and 2 (each within the scatter of the next). At a limit, below all of these: compound 3.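

The exchange shows that this position is not a neutral one in this assay: a 26-fold higher number from compound 1 to compound 4 (1.41 log units; beyond the scatter). With the methyl kept in place, the number therefore depends on the group at this position as well as on the methyl, whose removal gives a step of similar printed class, a 30-fold higher number from compound 1 to compound 2 (1.48 log units; beyond the scatter), so compound 1 loses most of its standing through either single change. Nothing available here accounts for the size of the step at this position, as the only supporting observation concerns a limit reached by a different compound and has no bearing on this pair.

The exchange alters both the substituent and where it sits on the ring, so the compounds shown cannot tell whether the large step follows from the loss of chlorine, the arrival of trifluoromethyl or the move of the substituent, and 4-chlorophenyl or 3-(trifluoromethyl)phenyl would separate these. As far as these compounds go, it also remains open how unsubstituted phenyl, or a phenyl ring carrying an amine or a carboxylic acid, would fare at this position with the methyl kept.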